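Serine-type analogue of a thiol amide: an expected small step

A few compounds are considered here, and "the series" means these few. Any claim that something is new, unique, unknown or untested is made for them only; others in the source may bear on it.

Measured in a functional assay on KB-V1 cells (Homo sapiens) for cytotoxicity, read by MTT assay, with a stated time of 72 h; a higher number here means a weaker inhibitor, a lower number a stronger inhibitor:
Compound 1 (`CC(S)CC(=O)NCC(=O)O`) gives 9240000 nM
Compound 2 (`CC(S)C(=O)N[C@@H](C)C(=O)O`) gives 490000 nM
Compound 3 (`CC(S)C(=O)N[C@H](C(=O)O)C(C)C`) gives 360000 nM

Compound 2 lies within the scatter of compound 3, and compound 1 shows a higher number than either. Compound 4 (`CC(S)C(=O)N[C@@H](CO)C(=O)O`) differs from compound 2 in one place (hydroxy in place of hydrogen on a saturated chain carbon, two bonds along the chain from an amide-type nitrogen and a carbonyl carbon), with hydroxy in place of hydrogen on a saturated chain carbon, so that methyl becomes hydroxymethyl. For the measured compounds named here, the one measured step that replaces this same methyl, with isopropyl (a 1.4-fold lower number from compound 2 to compound 3 (0.13 log units; within the scatter)), stayed within the scatter. No step beyond the scatter is therefore expected in this assay here. The estimated step is small (a 1.2-fold higher number from compound 2 to compound 4 (0.09 log units; within the scatter)) and lies within the scatter. Compound 4 is expected at 600000 nM (estimated range 220000 nM to 1600000 nM).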

Compound 4, half-maximal inhibitory concentration: 240000 nM
For compound 4 the middle estimate is 2.5-fold (0.40 log units) above the measured one; the measured number falls inside the stated range.
By their numbers in this assay, from the lowest: compounds 4, 3 and 2 (each within the scatter of the next, the first and the last beyond it); then compound 1.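

In this assay, hydroxy in place of hydrogen on this saturated chain carbon gives a 2.0-fold lower number from compound 2 to compound 4 (0.31 log units; beyond the scatter) and so, unlike the change to isopropyl, moves the number modestly beyond the scatter. Hydroxymethyl and isopropyl at this position are still not separated, with a 1.5-fold lower number from compound 3 to compound 4 (0.18 log units; within the scatter) as the step between them. No available evidence accounts for the change from methyl to hydroxymethyl. As far as these compounds go, it remains open whether an amine or a carboxylic acid in place of this hydroxy would lower the number further. Also open, from the compounds shown here alone, is how a longer chain carrying the hydroxy would read.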